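The compounds below may be only part of what the source reports. "The series", "measured", "known", "first", "only" and "open" are said of these compounds alone.

Measured compounds:
compound 1, `O=c1oc2ccccc2cc1-c1cn2nc(-c3c([O-])[o+]nn3-c3ccc(Cl)cc3)sc2n1`: > 80 ug/mL
compound 2, `COc1ccc(-n2n[o+]c([O-])c2-c2nn3cc(-c4cc5cc(Cl)ccc5oc4=O)nc3s2)cc1`: > 70 ug/mL

Both compounds were tested in a functional assay on HT-29 cells (Homo sapiens) for cytotoxicity, read by sulforhodamine B assay; a lower number here means that less compound is tolerated, a higher number that more compound is tolerated. For compound 1 the result is only a limit of the assay, not a number, namely > 80 ug/mL. For compound 2 the result is likewise only a limit, > 70 ug/mL. Compound 2 therefore stands at the limit of > 70 ug/mL in this assay, at which 1 of the 2 values shown sits. Compound 1 stands at the limit of > 80 ug/mL in this assay, at which 1 of the 2 values shown sits. For the measured compounds named here, since neither value is a number, no step between the two measured compounds can be given, and the two limits show only that both compounds were tolerated up to the amounts tested.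

Compound 3, `COc1ccc(-n2n[o+]c([O-])c2-c2nn3cc(-c4cc5cc(Br)ccc5oc4=O)nc3s2)cc1`, has not yet been measured in this assay. It differs from compound 2 in one place: bromo in place of chloro on an aromatic carbon. Going by the values given here, with no measured step to rest on, the change from compound 2 to compound 3 is expected to bring no shift beyond the usual scatter, that is, a step that the limit leaves unreadable from compound 2 to compound 3. Compound 3 is accordingly estimated at 90 ug/mL in this assay, with a range from 40 ug/mL to 200 ug/mL, and most likely the assay will again report only a limit.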

Compound 3, concentration lethal to 50% of the cells: > 80 ug/mL
Compound 3: no number, only a limit; the forecaster's own chance of this, stated with the estimate: 75%; the middle value does not contradict the limit.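

In this assay compound 3 gives only a limit, > 80 ug/mL, not a number. Compound 2 also gives only a limit, so no step can be read between compound 2 and compound 3 for bromo in place of chloro. The compounds shown leave open how much of any of them the cells tolerate, and whether that exchange changes it.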